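The source may hold more compounds than are shown below. What is called first, only, known or untested is meant among the compounds shown, and "the series" means these compounds.

Measured compounds:
- compound 1, `COC(=O)c1cc(CC(C)CN2C[C@@H]3CCCC[C@@H]3[C@H](C(=O)N3CCN(c4ccc([N+](=O)[O-])cc4)CC3)C2)cc(C(=O)OC)c1`: 1.35 nM
- compound 2, `C[C@@H](Cc1ccc2ocnc2c1)CN1C[C@@H]2CCCC[C@@H]2[C@H](C(=O)N2CCN(c3ccc(F)c(F)c3)CC2)C1`: 11 nM

In an assay on isolated protein for binding affinity to somatostatin receptor type 3 (Homo sapiens) (on this read-out lower numbers stand for tighter binding and higher numbers for weaker binding), compound 1 gives 1.35 nM. Compound 2 gives 11 nM, the higher of the two numbers, and its distance from compound 1 lies beyond the scatter, so compound 2 is the weaker binder of the pair. Going by the values given here, compound 1 and compound 2 differ in more than one place, so no single step between them can be read.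

Compound 3, `CCOc1ccc(C[C@H](C)CN2C[C@@H]3CCCC[C@@H]3[C@H](C(=O)N3CCN(c4ccc(F)c(F)c4)CC3)C2)cn1`, has not been measured. It differs from compound 2 in one place: 6-ethoxypyridin-3-yl in place of 1,3-benzoxazol-5-yl on a saturated chain carbon, three bonds along the chain from an amine nitrogen in a ring. Among the compounds with values here, there is no measured pair showing this change, so the size of the step is open. Within the data shown here, with no comparable step to rest on, the expected step in this assay from compound 2 to compound 3 is a 1.4-fold higher number from compound 2 to compound 3 (0.13 log units; within the scatter), a change expected to stay near the scatter. Compound 3 is estimated at 15 nM, within 4 nM to 55 nM.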

Compound 3, dissociation constant: 14.1 nM
For compound 3 the middle estimate is 1.1-fold (0.03 log units) above the measured one, within the range that was stated.
By their numbers in this assay, from the lowest: compound 1; then compounds 2 and 3 (each within the scatter of the next).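

In this assay, the first single-place comparison among these compounds gives a 1.3-fold higher number from compound 2 to compound 3 (0.11 log units; within the scatter), a step within the scatter, so 6-ethoxypyridin-3-yl and 1,3-benzoxazol-5-yl cannot be told apart at this position. On a saturated chain carbon, three bonds along the chain from an amine nitrogen in a ring, a single six-membered aromatic ring bearing an ethoxy group thus reads the same as the fused pair of aromatic rings it replaces, with the same heavy-atom count on both sides. Nothing at hand explains why the two groups read alike.

The steps linking compound 1 to the other two cannot be read, so its lower number cannot be assigned to either of the places where it differs. Going by these compounds, it also remains open whether this position would tolerate a group such as 6-methoxypyridin-3-yl, a plain phenyl, or one carrying a carboxylic acid or an amine.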